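The source may report more compounds than this note shows. Statements on the series, on what has been measured and on what is new or still open speak of the compounds shown alone.

Compound 1 `C#CCSc1cnc2ccccc2c1[Se]CC#CCBr` gives 0.3 ug/mL in a functional assay on CCRF-CEM cells (Homo sapiens) for cytotoxicity, read by sulforhodamine B assay, with a stated time of 72 h; a lower number here means a stronger inhibitor, a higher number a weaker inhibitor.
Compound 2 `C#CCSc1cnc2ccccc2c1[Se]CC#CCO` gives 3.2 ug/mL in this assay.
Compound 3 `C#CCSc1cnc2ccccc2c1SCC#CCO` gives 3.2 ug/mL in this assay.

Compound 3 stands level with compound 2 at the digits shown, the two together the highest of the three numbers; the only separated number is that of compound 1, an 11-fold higher number from compound 1 to compound 3 (1.03 log units; beyond the scatter). Compound 4 `CSc1cnc2ccccc2c1SCC#CCO` differs from compound 3 in one place: hydrogen in place of ethynyl on a saturated chain carbon bound to a sulfur. The measured steps touch other parts of the molecule: an 11-fold higher number from compound 1 to compound 2 (1.03 log units; beyond the scatter) concerns the hydroxy and bromo, while no change at the digits printed from compound 2 to compound 3 (within the scatter) concerns sulfur against selenium on an aromatic carbon. Among the measured compounds shown here, none alters the propargylsulfanyl group, so no step bears directly on this change. In this assay compound 4 is therefore expected close to compound 3, a 1.1-fold higher number from compound 3 to compound 4 (0.04 log units; within the scatter), with a wide range. The estimate for compound 4 is 3.5 ug/mL, between 1.5 ug/mL and 10 ug/mL.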

Compound 4, concentration for 50% inhibition: 2.3 ug/mL
Compound 4: the middle estimate sits 1.5-fold (0.18 log units) above what was measured, and the stated range covers the measured number.
By their numbers in this assay, from the lowest: compound 1; then compounds 4, 2 and 3 (each within the scatter of the next).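

With hydrogen in place of ethynyl on the saturated chain carbon bound to sulfur, the step is a 1.4-fold lower number from compound 3 to compound 4 (0.14 log units; within the scatter) in this assay. Among the compounds shown here, this is the first reading at this position: with the hydroxy chain in place, the propargylsulfanyl group can give way to methylsulfanyl without a separated change in the number. No measurement shown accounts for this result.

The compounds shown leave open how a longer chain or an amine on this sulfur would read. Going by these compounds, it also remains open whether the bromo-to-hydroxy step keeps its size with methylsulfanyl present.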